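Swapping the Aryl Group and Toxicity Toward HeLa Cells

The source may hold more compounds than are shown below. What is called first, only, known or untested is meant among the compounds shown, and "the series" means these compounds.

Compound 1 `Cc1nc(-c2cccnc2)sc1-c1nnc(-c2ccccc2)o1` and compound 2 `Cc1nc(-c2cccnc2)sc1-c1nnc(-c2cccc(Cl)c2Cl)o1` share one core and differ only in the aryl group attached to it. In an ADME assay on HeLa cells (Homo sapiens) for cytotoxicity, read by MTT assay (on this read-out lower numbers stand for higher toxicity in this test and higher numbers for lower toxicity in this test), compound 1 gives > 100 ug/mL, which is a limit of the assay rather than a number. Compound 2 likewise gives > 100 ug/mL, again a limit. The step that the two limits leave unreadable from compound 1 to compound 2 therefore cannot be read, and the limit of > 100 ug/mL in this assay, at which 2 of the 2 values shown sit, is all the evidence at hand. Compound 3 `Cc1ccc(-c2nnc(-c3sc(-c4cccnc4)nc3C)o2)cc1` carries 4-methylphenyl in place of 2,3-dichlorophenyl on an aromatic carbon. With no readable step to build on, the expected step that the limit leaves unreadable from compound 2 to compound 3 is none beyond the scatter. Compound 3 is therefore estimated at 150 ug/mL, within a range of 60 ug/mL to 400 ug/mL.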

Compound 3, half-maximal cytotoxic concentration: > 100 ug/mL
Compound 3: a limit, no number; the forecaster's own chance of this, stated with the estimate: 80%; the middle value is on the limit's open side.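

Within the data shown here, compound 3 gives > 100 ug/mL in this assay, again a limit and not a number, so no step among compound 1, compound 2 and compound 3 can be read. Left open is how far apart these compounds truly lie, because all three rest at one limit: the limit of > 100 ug/mL in this assay, at which 3 of the 3 values shown sit.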